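Dimethylamino for acetyl on the pendant phenyl ring

The compounds below may be only part of what the source reports. "The series", "measured", "known", "first", "only" and "open" are said of these compounds alone.

Working notes on a small set of pyrazole-linked compounds tested in a functional assay on NCI-H522 cells (Homo sapiens) for cytotoxicity, read by sulforhodamine B assay, with a stated time of 48 h, tested at 0.001 uM; a lower number here means a stronger effect, a higher number a weaker effect of the compound at the concentration tested. Compound 1 `COc1cc(C)cc(-c2c(-c3ccnc(-c4ccc(C(C)=O)cc4)c3)cnn2CC#N)c1` gives 86% in this assay. Compound 2 `Cc1cc(O)cc(-c2nn(CC#N)cc2-c2ccnc(-c3ccc(N(C)C)cc3)c2)c1` gives 87% in this assay; the two values sit within the usual scatter of each other, so neither compound can be set apart from the other on these numbers. Compound 3 `COc1cc(C)cc(-c2c(-c3ccnc(-c4ccc(N(C)C)cc4)c3)cnn2CC#N)c1` has not yet been measured. It differs from compound 1 in one place: dimethylamino in place of acetyl on an aromatic carbon. Compound 2 already carries the dimethylamino group on its pendant ring and its value in this assay lies with that of compound 1, so no step beyond the scatter is expected here. The step from compound 1 to compound 3 in this assay is estimated at no change at the digits printed from compound 1 to compound 3 (within the scatter). For compound 3 the expected value in this assay is 86%, with a range from 76% to 96%.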

Compound 3, a percentage reported as activity, at one concentration (the size of the read-out at that concentration, not a potency): 96%
Compound 3: the middle estimate sits 10 percentage points below what was measured; the measured number falls inside the stated range.
By their numbers in this assay, from the lowest: compounds 1, 2 and 3 (each within the scatter of the next).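

With the rest of the structure held constant, replacing 4-acetylphenyl with 4-(dimethylamino)phenyl gives, in this assay, a number 10 percentage points higher from compound 1 to compound 3 (within the scatter). Among these compounds, this is the first comparison in the set that isolates this change at this aromatic carbon, since the earlier pair differed in more than one place and could not do so. At this single test concentration, the step does not separate dimethylamino from acetyl, and nothing measured here offers an explanation for the result.

From the compounds shown here alone, it remains open whether a carboxylic acid or a longer amine chain on the same aromatic carbon would produce a step beyond the scatter. Also open, going by these compounds, is whether acetyl and dimethylamino would remain inseparable at other concentrations, where one might give a stronger or weaker effect than the other.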